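Two inactive uracils and a silyl-protected analogue

The source may hold more compounds than are shown below. What is called first, only, known or untested is meant among the compounds shown, and "the series" means these compounds.

Measured so far:
compound 1 `O=c1cc(CC(COCc2ccccc2)COCc2ccccc2)[nH]c(=O)[nH]1` gives > 100000 nM
compound 2 `Cc1c(CC(O)COCc2ccccc2)[nH]c(=O)[nH]c1=O` gives > 100000 nM

Both values come from a functional assay on MCF7 cells (Homo sapiens) for antiproliferative activity, read by MTT assay, with a stated time of 72 h; on this read-out higher numbers stand for weaker inhibition and lower numbers for stronger inhibition. Compound 1 gives > 100000 nM, which is a limit of the assay and not a number. Compound 2 likewise gives > 100000 nM, again a limit rather than a measured number. On the numbers shown, compound 2 therefore stands at the edge of what the assay can report, in keeping with the limit of > 100000 nM in this assay, at which 2 of the 2 values shown sit, and nothing distinguishes it from compound 1.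

Compound 3 `Cc1c(CC(O)COCc2ccccc2)n(COCC[Si](C)(C)C)c(=O)[nH]c1=O` is not yet measured. It differs from compound 2 by a group of 8 heavy atoms (6 carbon, 1 oxygen, 1 silicon; no ring) in place of a hydrogen atom, on an aromatic nitrogen. Among the measured compounds shown here, no step between measured compounds is available to say what such a change does here. Starting from a limit, no step beyond the scatter is expected in either direction, and the expected step is a number no higher from compound 2 to compound 3 (the limit leaves the size open). Compound 3 is accordingly estimated at 100000 nM, with a range from 20000 nM to 300000 nM, most likely reported again as a limit.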

Compound 3, half-maximal inhibitory concentration: > 100000 nM
Compound 3: only a limit was reported (the forecaster's own chance of this, stated with the estimate: 70%); the middle value lies on the limit itself.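

In this assay compound 3 gives > 100000 nM, which is a limit and not a number. Compound 2 also sits at a limit, so no step can be read from compound 2 to compound 3. The compounds shown leave open whether any change to the shared core, including the group on the aromatic nitrogen, alters the result in this assay.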